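Cyclohexyl to phenethyl on the thioether arm of compound 1

The source may report more compounds than this note shows. Statements on the series, on what has been measured and on what is new or still open speak of the compounds shown alone.

Compound 1 `Cc1cc(N2CC[C@@H](C)[C@@H](N(C)c3ncnc4[nH]ccc34)C2)n2nc(SCC3CCCCC3)nc2n1` is the reference point of this set. In a functional assay on BGC-823 cells (Homo sapiens) for inhibition, read by MTT assay, with a stated time of 72 h (on this read-out higher numbers stand for weaker inhibition and lower numbers for stronger inhibition), compound 1 gives 16300 nM. Two related compounds have also been measured. Compound 3 `Cc1cc(N2CC[C@@H](C)[C@@H](N(C)c3ncnc4[nH]ccc34)C2)n2nc(SCc3cc(Cl)ccc3Cl)nc2n1` gives 18900 nM, and the step of a 1.2-fold higher number from compound 1 to compound 3 (0.06 log units; within the scatter). Compound 2 `CCCCCc1c(C)nc2nc(SCc3ccc(Cl)cc3)nn2c1N1CC[C@@H](C)[C@@H](N(C)c2ncnc3[nH]ccc23)C1` differs from compound 1 in several places at once. In this assay compound 2 gives 32300 nM. All three numbers sit within the scatter of one another, with compound 1 at one end of the spread, so no ranking among them can be drawn.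

Compound 4 `Cc1cc(N2CC[C@@H](C)[C@@H](N(C)c3ncnc4[nH]ccc34)C2)n2nc(SCCCc3ccccc3)nc2n1` has not yet been measured. Relative to compound 1 the change is phenethyl in place of cyclohexyl on a saturated chain carbon bound to a sulfur. Within the data shown here, the only measured step that bears on this position is the one from compound 1 to compound 3, and it stayed within the scatter. With nothing to suggest otherwise, compound 4 is expected to behave much like compound 1, with the step of a 1.0-fold higher number from compound 1 to compound 4 (0.02 log units; within the scatter) expected to be no larger than the scatter. The estimate for compound 4 is therefore 17000 nM, between 7000 nM and 40000 nM.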

Compound 4, half-maximal inhibitory concentration: > 100000 nM
Compound 4 ended at the assay's limit (the forecaster's own chance of this, stated with the estimate: 5%); middle value at least 5.8-fold (0.76 log units) from the limit.
By their numbers in this assay, from the lowest: compounds 1, 3 and 2 (each within the scatter of the next). At a limit, above all of these: compound 4.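

Among these compounds, the position on a saturated chain carbon bound to a sulfur is less tolerant than the earlier compounds suggested: an at least 6.1-fold higher number from compound 1 to compound 4 (0.78 log units; beyond the scatter) and an at least 5.2-fold higher number from compound 3 to compound 4 (0.72 log units; beyond the scatter), both beyond the scatter, whereas the step from cyclohexyl to 2,5-dichlorophenyl stayed within it. An aromatic ring alone does not go with the loss, since compound 3 also carries one and stays within the scatter of compound 1. The true size of both steps cannot be read, as compound 4 stands at a limit rather than at a number: the limit of > 100000 nM in this assay, at which 1 of the 4 values shown sits.

Whether the longer chain or the chlorine-free phenyl ring accounts for the loss stays open, and a 3-cyclohexylpropyl arm or an unsubstituted benzyl arm would separate the two. Also open, as far as these compounds go, is how an amine or a carboxylic acid on this arm would read.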